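The source may report more compounds than this note shows. Statements on the series, on what has been measured and on what is new or still open speak of the compounds shown alone.

Two compounds were measured in an assay on microsomes from liver for inhibition of 3-hydroxy-3-methylglutaryl-coenzyme A reductase (Rattus norvegicus); a lower number here means a stronger inhibitor, a higher number a weaker inhibitor:

Compound 1, `CC(C)c1c(C(=O)NCc2cccc(F)c2F)nn(-c2ccc(F)cc2)c1OC[C@@H](O)C[C@@H](O)CC(=O)O`: 2 nM
Compound 2, `CC(C)c1c(C(=O)NCc2ccc(Cl)cc2)nn(-c2ccc(F)cc2)c1OC[C@@H](O)C[C@@H](O)CC(=O)O`: 6.7 nM

Compound 2 gives the higher of the two numbers; compound 1 sits a 3.4-fold higher number from compound 1 to compound 2 (0.53 log units; beyond the scatter) away. Compound 3, `Cc1cccc(CN(C)C(=O)c2nn(-c3ccc(F)cc3)c(OC[C@@H](O)C[C@@H](O)CC(=O)O)c2C(C)C)c1`, differs from compound 2 by methyl(3-methylbenzyl)amino in place of (4-chlorobenzyl)amino on a carbonyl carbon. Within the data shown here, the only measured step, a 3.4-fold higher number from compound 1 to compound 2 (0.53 log units; beyond the scatter), concerns a change on the benzyl ring alone, and no measured pair covers a methyl on the amide nitrogen. The expectation for compound 3 is therefore a modest weakening beyond the scatter, a 4.5-fold higher number from compound 2 to compound 3 (0.65 log units; beyond the scatter), with wide uncertainty. Compound 3 is estimated at 30 nM, within 8 nM to 150 nM.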

Compound 3, half-maximal inhibitory concentration: 37 nM
Compound 3: middle estimate off by 1.2-fold (0.09 log units), on the low side; low and high end bracket the measured number.
By their numbers in this assay, from the lowest: compound 1; then compound 2; then compound 3.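

In this assay, methyl(3-methylbenzyl)amino in place of (4-chlorobenzyl)amino on the carbonyl carbon gives a clear weakening (a 5.5-fold higher number from compound 2 to compound 3 (0.74 log units; beyond the scatter)), and the same group in place of (2,3-difluorobenzyl)amino gives a larger one (a 19-fold higher number from compound 1 to compound 3 (1.27 log units; beyond the scatter)). The position therefore tolerates this change less well than the earlier ring change alone, and the amide hydrogen is lost in the same step. Nothing available explains this weakening. The methyl on the amide nitrogen and the new ring substitution arrive together, so the compounds shown cannot separate their contributions. From the compounds shown here alone, how an ethyl group on that nitrogen would compare remains open.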